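Trifluoromethoxy for phenoxy on a triazole-linked aryl pair

This account rests on a few compounds, and the source may have more. Where it says the series, first, only, none or still open, it means among the compounds named here.

Measured compounds:
compound 1, `COc1ccc(-c2cn(-c3ccc(Oc4ccccc4)cc3)nn2)cc1` — > 100 nM in a functional assay on MDA-MB-231 cells (Homo sapiens) for cytotoxicity, read by MTT assay; on this read-out higher numbers stand for weaker inhibition and lower numbers for stronger inhibition
compound 2, `COc1cc(OC)cc(-c2cn(-c3ccc(Oc4ccccc4)cc3)nn2)c1` — > 10000 nM in this assay
compound 3, `COc1ccc(-c2cn(-c3ccc(OC(F)(F)F)cc3)nn2)cc1` — 1000 nM in this assay

The value of compound 1 is a limit of the assay and not a number (the limit of > 100 nM in this assay, at which 1 of the 3 values shown sits). The value of compound 2 is likewise a limit of the assay (the limit of > 10000 nM in this assay, at which 1 of the 3 values shown sits). Compound 3 is the only one of the three with a numerical value in this assay.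

From compound 1 to compound 3 the change is trifluoromethyl in place of phenyl on an oxygen on an aromatic ring, and the step it made, a step that the limit leaves unreadable from compound 1 to compound 3, cannot be sized because the value of compound 1 is a limit (the limit of > 100 nM in this assay, at which 1 of the 3 values shown sits).

The difference between the cores of compound 1 and compound 2 is not broken down here.

Compound 4, `COc1cc(OC)cc(-c2cn(-c3ccc(OC(F)(F)F)cc3)nn2)c1`, is not yet measured. It arises from compound 2 by trifluoromethyl in place of phenyl on an oxygen on an aromatic ring, the same change as that from compound 1 to compound 3. Since compound 2 already sits at a limit (the limit of > 10000 nM in this assay, at which 1 of the 3 values shown sits), and the earlier step is unreadable, the size expected from compound 2 to compound 4 is anchored only on that limit and is estimated as a step that the limit leaves unreadable from compound 2 to compound 4. Compound 4 is therefore expected to give about 15000 nM in this assay, between 4000 nM and 60000 nM.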

Compound 4, half-maximal inhibitory concentration: > 1000 nM
Compound 4: only a limit was reported (the forecaster's own chance of this, stated with the estimate: 70%); the middle value lies beyond the limit too.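

In this assay compound 4 gives > 1000 nM, which is a limit of the assay and not a number. Compound 2 also stands at a limit, and no step can be read from compound 2 to compound 4. The compounds shown leave open how large the change from phenoxy to trifluoromethoxy is on either core, and in which direction it goes.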